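The source may report more compounds than this note shows. Statements on the series, on what has been measured and on what is new or still open speak of the compounds shown alone.

Working notes on the series.

Compound 1 `CC(C)(C)c1ccc(C(=O)N2CCC3(CC2)C(=O)N(CC(=O)N2CCC(CCO)CC2)CN3c2ccccc2)cc1` is the reference point. In an assay on HEK293 cells for displacement of a labelled ligand from NPC1-like intracellular cholesterol transporter 1 (Homo sapiens) (on this read-out higher numbers stand for weaker inhibition and lower numbers for stronger inhibition), compound 1 gives 2600 nM, the lowest of the three numbers recorded so far. Compound 2 `CC(C)(C)c1ccc(C(=O)N2CCC3(CC2)C(=O)N(CC(=O)N2CCN(S(C)(=O)=O)CC2)CN3c2ccccc2)cc1`, with 4-(methylsulfonyl)piperazin-1-yl in place of 4-(2-hydroxyethyl)piperidin-1-yl on the carbonyl carbon, gives 19000 nM in this assay; the step of a 7.3-fold higher number from compound 1 to compound 2 (0.86 log units; beyond the scatter). Compound 3 `CC(C)(C)c1ccc(C(=O)N2CCC3(CC2)C(=O)N(CC(=O)NCCCCNS(C)(=O)=O)CN3c2ccccc2)cc1`, with (4-(methanesulfonamido)butyl)amino on that carbonyl carbon, gives 4500 nM, and a 1.7-fold higher number from compound 1 to compound 3 (0.24 log units; within the scatter); between the two variants, a 4.2-fold lower number from compound 2 to compound 3 (0.63 log units; beyond the scatter).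

Compound 4 `CCc1nn(CC)c(C2CCN(C(=O)CN3CN(c4ccccc4)C4(CCN(C(=O)c5ccc(C(C)(C)C)cc5)CC4)C3=O)CC2)c1C` keeps the core of compound 1 and alters only the piperidine substituent: 1,3-diethyl-4-methyl-1H-pyrazol-5-yl in place of 2-hydroxyethyl on a saturated ring carbon. Going by the values given here, none of the measured steps makes this particular change; the two known steps out of compound 1 replace the whole amide substituent, one staying within the scatter and one a modest loss. They show that this end of the molecule tolerates variation with modest consequences, and nothing measured points toward a gain. The expectation for compound 4 in this assay is therefore a small to modest move toward weaker inhibition, a 1.7-fold higher number from compound 1 to compound 4 (0.24 log units; within the scatter), with wide uncertainty. Compound 4 is estimated at 4500 nM, in the range 1200 nM to 18000 nM.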

Compound 4, half-maximal inhibitory concentration: 2500 nM
Beside the measured number, compound 4's estimate is 1.8-fold (0.26 log units) above it, and the stated range covers the measured number.
By their numbers in this assay, from the lowest: compounds 4, 1 and 3 (each within the scatter of the next); then compound 2.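

In this assay, 1,3-diethyl-4-methyl-1H-pyrazol-5-yl in place of 2-hydroxyethyl on the saturated ring carbon gives a 1.0-fold lower number from compound 1 to compound 4 (0.02 log units; within the scatter), so this position accepts a group of 10 heavy atoms in place of one of 3 without a step beyond the scatter. The entering group has 0 hydrogen-bond donors and a five-membered aromatic ring, whereas the leaving group has 1 hydrogen-bond donor and no ring, so for this pair neither the donor of 2-hydroxyethyl nor the absence of a ring is needed to keep the number at the level of compound 1. No measurement on hand offers an explanation for why this large change leaves the number in place.

From the compounds shown here alone, it remains open whether an amine, a carboxylic acid or a plain phenyl ring on this same ring carbon would also leave the number in place. Going by these compounds, it is also open whether the substituents on the pyrazole matter, for instance whether a ring carrying only methyl groups instead of the two ethyl groups would behave like 1,3-diethyl-4-methyl-1H-pyrazol-5-yl.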